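Benzyloxy for propyl on the hydroxypropyl chain

The source may report more compounds than this note shows. Statements on the series, on what has been measured and on what is new or still open speak of the compounds shown alone.

Of the compounds shown here, three have been read in an assay on nucleic acid for inhibition of Nucleic Acid, read by fluorescence, tested at 100 uM; a lower number here means less inhibition, a higher number more inhibition at the concentration tested (going by the name of the read-out). Compound 1 `OC(COCc1ccccc1)Cn1cc(CN2CCN(c3ccccc3)CC2)nn1` gives 37%, compound 2 `CCCCC(O)Cn1cc(CN2CCN(c3ccccc3)CC2)nn1` gives 47%, and compound 3 `CCCCC(O)Cn1cc(CN2CCCC(C(=O)OCC)C2)nn1` gives 53%. The difference between the cores of compound 2 and compound 3 is not broken down here. From compound 2 to compound 1 the change is benzyloxy in place of propyl on a saturated chain carbon, two bonds along the chain from an oxygen on a saturated carbon; it gave a number 10 percentage points lower from compound 2 to compound 1 (within the scatter). Compound 4 `CCOC(=O)C1CCCN(Cc2cn(CC(O)COCc3ccccc3)nn2)C1` is not yet measured; it carries the same change on the core of compound 3, (benzyloxy in place of propyl on a saturated chain carbon, two bonds along the chain from an oxygen on a saturated carbon), and the two place descriptions agree word for word. Going by the values given here, the only measured instance of this change is a number 10 percentage points lower from compound 2 to compound 1 (within the scatter). In this assay the step from compound 3 to compound 4 is expected to be of about the same size as that measured instance. For compound 4 the estimate is 43%, from 30% to 56%, an expected step of a number 10 percentage points lower from compound 3 to compound 4 (within the scatter).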

Compound 4, a percentage reported as inhibition, at one concentration (the size of the read-out at that concentration, not a potency): 26%
Estimate against measurement, compound 4: 17 percentage points above, outside the stated range (below it).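

In this assay the change of propyl to benzyloxy does not carry from one core to the other at a fixed size: the same change on two cores in this assay, a number 10 percentage points lower (within the scatter) from compound 2 to compound 1 and a number 27 percentage points lower (beyond the scatter) from compound 3 to compound 4, 17 percentage points apart, beyond the scatter of two such steps On the core of compound 3 the step is a number 27 percentage points lower from compound 3 to compound 4 (beyond the scatter), so the step on the core of compound 2 is a poor guide to its size on this core. With one pair on each core, this shows only that the size of the step differed between these two cores; it does not show which part of the cores accounts for the gap, or what the change would do on a third core.

Still open, as far as these compounds go, is how a longer chain in place of propyl would read on either core. Also open, from the compounds shown here alone, is whether a carboxylic acid in place of the ester of compound 3 would alter the step.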